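Chloro for tert-butyl in a K562 antiproliferative series

A few compounds are considered here, and "the series" means these few. Any claim that something is new, unique, unknown or untested is made for them only; others in the source may bear on it.

Measured so far:
compound 1 `Cc1cn(-c2cc(NC(=O)c3ccc(C)c(Nc4nc(-c5cccnc5)cs4)c3)cc(C(C)C)c2)cn1` — 31 nM
compound 2 `Cc1cn(-c2cc(NC(=O)c3ccc(C)c(Nc4nc(-c5cccnc5)cs4)c3)cc(C(C)(C)C)c2)cn1` — 10 nM

In a functional assay on K562 cells (Homo sapiens) for antiproliferative activity (a lower number here means a stronger inhibitor, a higher number a weaker inhibitor), compound 2 gives 10 nM, the lowest of the two numbers shown; its nearest neighbour is compound 1, and the step of a 3.1-fold lower number from compound 1 to compound 2 (0.49 log units; beyond the scatter) lies beyond the scatter. Compound 3 `Cc1cn(-c2cc(Cl)cc(NC(=O)c3ccc(C)c(Nc4nc(-c5cccnc5)cs4)c3)c2)cn1` carries the change chloro in place of tert-butyl on an aromatic carbon on the same ring. For the measured compounds named here, the only measured step that bears on this position is a 3.1-fold lower number from compound 1 to compound 2 (0.49 log units; beyond the scatter), where a larger group at that carbon gave a lower number. Chloro is a smaller group than either, so the expected direction is a higher number, and with a single step as guide the size is taken as modest rather than large. Compound 3 is therefore expected to give about 40 nM in this assay, within 12 nM to 130 nM, an estimated step of a 4.0-fold higher number from compound 2 to compound 3 (0.60 log units; beyond the scatter).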

Compound 3, half-maximal inhibitory concentration: 812 nM
Beside the measured number, compound 3's estimate is 20-fold (1.31 log units) below it; measured number outside the range, above it.
By their numbers in this assay, from the lowest: compound 2; then compound 1; then compound 3.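

In this assay, this aromatic carbon proves far less tolerant than the isopropyl and tert-butyl pair alone indicated: chloro in place of tert-butyl gives an 81-fold higher number from compound 2 to compound 3 (1.91 log units; beyond the scatter), and chloro in place of isopropyl gives a 26-fold higher number from compound 1 to compound 3 (1.42 log units; beyond the scatter). Both steps are large, whereas the step between the two alkyl groups is modest, so most of the sensitivity at this carbon appears only on leaving the branched alkyl groups. No supporting measurement here explains the loss.

As far as these compounds go, whether the rise follows the drop in group size or the switch from a saturated chain to a halogen remains open. A methyl or a bromo at this carbon, on the same core, would separate these two readings.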